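The source may report more compounds than this note shows. Statements on the series, on what has been measured and on what is new or still open speak of the compounds shown alone.

Compound 1 `CC(C)Oc1cccc(-c2ccc(C(=O)N(Cc3cccc(OCCCCCC(=O)O)c3)C(C)C)cc2)c1`. In an ADME assay on HepG2 cells (Homo sapiens) for cytotoxicity, read by CellTiter-Glo and resazurin assay, with a stated time of 72 h (a higher number here means that more compound is needed for the effect, a lower number that less compound is needed), compound 1 gives > 26000 nM, a limit of the assay.
Compound 2 `CCOC(=O)CCCCCOc1cccc(CN(C(=O)c2ccccc2)C(C)C)c1`. Compound 2 gives > 26000 nM, a limit.
Compound 3 `CCOC(=O)CCCCCOc1cccc(CN(C(=O)c2ccc(-c3cnc(OC)nc3OC)cc2)C(C)C)c1`. Compound 3 gives > 26000 nM, a limit.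

Among the compounds with values here, compound 3 thus stands at the limit shared by every value so far (the limit of > 26000 nM in this assay, at which 3 of the 3 values shown sit); no number separates it from the others. The next compound, compound 4 `CCOC(=O)CCCCCOc1cccc(CN(C(=O)c2ccc(-c3cccc(OC(C)C)c3)cc2)C(C)C)c1`, differs from it by 3-isopropoxyphenyl in place of 2,4-dimethoxypyrimidin-5-yl on an aromatic carbon. Within the data shown here, the only measured step on this part of the core, a step that the two limits leave unreadable from compound 2 to compound 3, is unreadable since both ends sit at the limit. Compound 1 also carries the 3-isopropoxyphenyl group, with the acid rather than the ester on the chain, and likewise gives only a limit. No readable step is therefore expected for compound 4, and the change a number no higher from compound 3 to compound 4 (the limit leaves the size open) is estimated as none beyond the scatter. Compound 4 is expected at about 26000 nM, within 13000 nM to 52000 nM, most probably again reported as a limit.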

Compound 4, half-maximal effective concentration: > 26000 nM
Compound 4: a limit, no number; the forecaster's own chance of this, stated with the estimate: 85%; the middle value sits exactly at the limit.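

Within the data shown here, compound 4 gives > 26000 nM as a limit, so no step linking it to compound 1, compound 2 or compound 3 can be read: the limit of > 26000 nM in this assay, at which 4 of the 4 values shown sit. In this assay the compounds shown leave open the concentration at which any of them reaches the half-maximal effect.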